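The compounds below may be only part of what the source reports. "The series", "measured", "known", "first", "only" and "open" are said of these compounds alone.

For the measured compounds named here, in a functional assay on MCF7 cells (Homo sapiens) for cytotoxicity, read by CCK-8 assay, with a stated time of 48 h (on this read-out lower numbers stand for stronger inhibition and higher numbers for weaker inhibition), compound 2 `Cc1cc(C)nc(NS(=O)(=O)c2ccc(/N=C/c3c(Cl)c4ccccc4oc3=O)cc2)n1` gives 20 nM, the lowest of the two numbers available so far. The other measured compound, compound 1 `NS(=O)(=O)c1ccc(/N=C/c2c(Cl)c3ccccc3oc2=O)cc1`, gives 120 nM in this assay. Going by the values given here, the only measured step is a 6.0-fold lower number from compound 1 to compound 2 (0.78 log units; beyond the scatter), which introduces the whole 4,6-dimethylpyrimidin-2-yl group on the sulfonamide nitrogen. Compound 3 `Cc1ccnc(NS(=O)(=O)c2ccc(/N=C/c3c(Cl)c4ccccc4oc3=O)cc2)n1` keeps that arrangement and differs from compound 2 by hydrogen in place of methyl on an aromatic carbon. Among the compounds with values here, no measured pair isolates the loss of a single methyl from this ring, so the step from compound 1 to compound 2 bears on it only loosely: it shows that the substituted sulfonamide gave the lower number, but says nothing about what each methyl contributes. Removing one methyl is a far smaller change than adding the whole substituted ring, so the expected step is a 1.5-fold higher number from compound 2 to compound 3 (0.18 log units; within the scatter), a shift that need not leave the scatter and, if anything, leans toward a slightly higher number. Compound 3 is therefore estimated at 30 nM in this assay, with a range from 10 nM to 90 nM.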

Compound 3, half-maximal inhibitory concentration: 31 nM
Estimate against measurement, compound 3: 1.0-fold (0.01 log units) below; measured number inside the range.
By their numbers in this assay, from the lowest: compounds 2 and 3 (each within the scatter of the next); then compound 1.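

In this assay, the step of a 1.6-fold higher number from compound 2 to compound 3 (0.19 log units; within the scatter) gives the first direct reading of a single methyl on the ring, at the carbon next to the ring nitrogen, and it does not leave the scatter, so this methyl is not shown to matter for the number in this assay. The step of a 3.9-fold lower number from compound 1 to compound 3 (0.59 log units; beyond the scatter) shows that the lower number relative to compound 1 does not need both methyl groups, since the 4-methylpyrimidin-2-yl group on the sulfonamide nitrogen still gives a step beyond the scatter. No measurement at hand gives a reason for either step.

The compounds shown leave open what the remaining methyl contributes, and whether a plain pyrimidin-2-yl group with no methyl at all would stay apart from compound 1 by more than the scatter. They also leave open whether a different group at this carbon, such as an ethyl, a methoxy or an amine, would move the number beyond the scatter, and whether another ring on the sulfonamide nitrogen, such as a pyridine, would do the same.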